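Replacing naphthalen-2-yl in compound 2 with 4-methoxyphenyl

This account rests on a few compounds, and the source may have more. Where it says the series, first, only, none or still open, it means among the compounds named here.

In a functional assay on SK-MEL-2 cells (Homo sapiens) for inhibition, read by sulforhodamine B assay, with a stated time of 72 h (a higher number here means a weaker inhibitor, a lower number a stronger inhibitor), compound 1 (`COc1ccc(CN(Cc2ccccc2)Cc2c(O)ccc3c(=O)cc(C)oc23)cc1`) gives 78.6 ug/mL as its half-maximal inhibitory concentration. Compound 2 (`COc1ccc(CN(Cc2ccc3ccccc3c2)Cc2c(O)ccc3c(=O)cc(C)oc23)cc1`) gives > 100 ug/mL as a limit of the assay and not as a number, and it stands at the limit of > 100 ug/mL in this assay, at which 1 of the 2 values shown sits, in the series. Compound 3 (`COc1ccc(CN(Cc2ccc(OC)cc2)Cc2c(O)ccc3c(=O)cc(C)oc23)cc1`) carries 4-methoxyphenyl in place of naphthalen-2-yl on a saturated chain carbon bound to an amine nitrogen. Among the measured compounds shown here, the one measured step at this place, naphthalen-2-yl in place of phenyl, is an at least 1.2-fold higher number from compound 1 to compound 2 (0.10 log units; that floor lies within the scatter) and its floor lies within the scatter. Compound 1, at 78.6 ug/mL with phenyl at this place, is the closest measured reference. The expected move in this assay is therefore small and toward a lower number, an estimated at least 1.2-fold lower number from compound 2 to compound 3 (0.09 log units; that floor lies within the scatter) that may not clear the scatter. For compound 3 the estimated value is 80 ug/mL (expected range 45 ug/mL to 130 ug/mL).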

Compound 3, half-maximal inhibitory concentration: 31.7 ug/mL
Compound 3: middle estimate off by 2.5-fold (0.40 log units), on the high side, and the stated range ends above it.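

In this assay, this position now shows a change beyond the scatter: 4-methoxyphenyl in place of naphthalen-2-yl gives an at least 3.1-fold lower number from compound 2 to compound 3 (0.49 log units; beyond the scatter), and methoxy in place of hydrogen on an aromatic carbon gives a 2.5-fold lower number from compound 1 to compound 3 (0.39 log units; beyond the scatter). The earlier phenyl to naphthalen-2-yl step had only a floor within the scatter, whereas the single methoxy now separates two measured values on the same core. Compound 2 carries a limit of the assay and not a number, so the larger step is a floor only: the limit of > 100 ug/mL in this assay, at which 1 of the 3 values shown sits.

As far as these compounds go, whether a fluorine, a hydroxy group or a longer alkoxy chain in place of the methoxy would keep the lower number stays open. Also open, from the compounds shown here alone, is whether a saturated ring such as cyclohexyl could stand in place of 4-methoxyphenyl at this position.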